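Moving a Hydroxyl Around the Phenyl Ring

The compounds below may be only part of what the source reports. "The series", "measured", "known", "first", "only" and "open" are said of these compounds alone.

Measured so far:
compound 1 `Cn1cnc2c(N3CCCCC3)nc(-c3ccccc3O)nc21` — 30.2%
compound 2 `CN1CCN(c2nc(-c3ccc(Cl)cc3)nc3[nH]cnc23)CC1` — 6.2%
compound 3 `CN1CCN(c2nc(-c3cccc(Cl)c3)nc3c2ncn3C)CC1` — 19.2%

Of the compounds shown here, three have been tested in an assay on cells for displacement of a labelled ligand from adenosine receptor A2b (Homo sapiens), read by scintillation counting and radioligand binding, with a stated time of 30 min, tested at 10 uM; a lower number here means less inhibition, a higher number more inhibition at the concentration tested (going by the name of the read-out). Compound 1 gives 30.2%, the highest of the three numbers. Compound 3 gives 19.2%, a number that lies below compound 1 by more than the usual scatter. Compound 2 gives 6.2%, the lowest of the set and again beyond the scatter from compound 1. Among the compounds with values here, since compounds 2 and 3 carry different cores and different substituents from compound 1, no single change links any two of the measured compounds, so these values show only a spread and no isolated step.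

The next compound, compound 4 `Cn1cnc2c(N3CCCCC3)nc(-c3cccc(O)c3)nc21`, keeps the core of compound 1 and the piperidin-1-yl group and changes only one thing: 3-hydroxyphenyl in place of 2-hydroxyphenyl on an aromatic carbon. The hydroxyl therefore moves from the 2-position to the 3-position of the phenyl ring that sits on the aromatic carbon between two ring nitrogen atoms.

Within the data shown here, with no comparable step among the measured compounds, the expectation rests on compound 1 alone. A modest fall is expected, and the step of a number 8.2 percentage points lower from compound 1 to compound 4 (within the scatter) is estimated to be small relative to the scatter. Compound 4 is thus expected to give 22%, within a range from 5% to 45%.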

Compound 4, a percentage reported as inhibition, at one concentration (the size of the read-out at that concentration, not a potency): 29.3%
Estimate against measurement, compound 4: 7.3 percentage points below; measured number inside the range.
By their numbers in this assay, from the lowest: compound 2; then compound 3; then compounds 4 and 1 (each within the scatter of the next).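

In this assay, within the data shown here, the move from 2-hydroxyphenyl to 3-hydroxyphenyl gives a number 0.9 percentage points lower from compound 1 to compound 4 (within the scatter), the first step in this set that isolates one change at one place. With the core of compound 1 and the piperidin-1-yl group held fixed, this read-out therefore does not separate the two hydroxyl placements on the aromatic carbon between two ring nitrogen atoms: the same atoms, joined differently, give numbers within the scatter of each other. This is a new kind of information, since the earlier compounds showed only a spread across different cores and substituents, and nothing at hand offers an explanation for the result.

The compounds shown leave open whether the hydroxyl matters at all on this phenyl ring, as neither a methoxy group nor an amine in its place, nor a plain phenyl ring, appears among them. Among these compounds, they also leave open how the number would respond to a change at the other substituent, such as a morpholine ring or a longer alkyl chain in place of the piperidin-1-yl group, and a reading at one concentration gives no potency for either compound.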